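The source may hold more compounds than are shown below. What is called first, only, known or untested is meant among the compounds shown, and "the series" means these compounds.

Compound 1 `COc1cccc(N2C(=O)COc3ccc(-c4cnc(Cl)c(NS(=O)(=O)c5ccc(F)cc5)c4)cc32)c1` reaches only the limit of a functional assay on A-375 cells (Homo sapiens) for antiproliferative activity, read by MTT assay, with a stated time of 72 h (a lower number here means a stronger inhibitor, a higher number a weaker inhibitor), reported as > 40000 nM. Going by the values given here, compound 2 `COc1ccc(N2C(=O)COc3ccc(-c4cnc(OC)c(NS(=O)(=O)c5ccc(F)cc5)c4)cc32)cc1` gives 18400 nM in this assay, the only numerical value among the two measured compounds. Compound 3 `COc1ncc(-c2ccc3c(c2)N(c2ccc(F)cc2)C(=O)CO3)cc1NS(=O)(=O)c1ccc(F)cc1` differs from compound 2 by fluoro in place of methoxy on an aromatic carbon. Among the compounds with values here, with no measured step between compounds differing only at this position, a change in this assay beyond the usual scatter is not expected in either direction. Compound 3 is therefore estimated at 20000 nM, with a range from 8000 nM to 50000 nM, and the expected step is a 1.1-fold higher number from compound 2 to compound 3 (0.04 log units; within the scatter).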

Compound 3, half-maximal inhibitory concentration: > 40000 nM
Compound 3: no number, only a limit; the forecaster's own chance of this, stated with the estimate: 30%; at least 2.0-fold (0.30 log units) between middle value and limit.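

Going by these compounds alone, this is the first measured step at this place, para to a large group on the six-membered aromatic ring of carbon only. In this assay, going from 4-methoxyphenyl to 4-fluorophenyl is not a neutral change: it gives an at least 2.1-fold higher number from compound 2 to compound 3 (0.33 log units; beyond the scatter). That step is only a bound, because compound 3 gives a limit and not a number: the limit of > 40000 nM in this assay, at which 2 of the 3 values shown sit.

A single step cannot show whether the methoxy group itself is what counts here. As far as these compounds go, how an amine or a longer ether chain such as ethoxy would read at this place remains open.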